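The compounds below may be only part of what the source reports. "The series", "measured", "known", "first", "only" and "open" are said of these compounds alone.

Compound 2 `Cn1c(-c2ccc(NC(=O)CN3CCN(c4ccccc4)CC3)cc2)nc(-c2ccccc2)c1-c1ccccc1` gives 60.5% in a functional assay on HT-29 cells (Homo sapiens) for cytotoxicity, read by MTT assay, with a stated time of 24 h, tested at 32 ug/mL (a lower number here means a weaker effect, a higher number a stronger effect of the compound at the concentration tested), the highest of the two numbers in hand; compound 1 `CCN1CCN(CC(=O)Nc2ccc(-c3nc(-c4ccccc4)c(-c4ccccc4)n3C)cc2)CC1` gives 38.8%, and the step of a number 21.7 percentage points higher from compound 1 to compound 2 (beyond the scatter) lies beyond the scatter. Compound 3 `Cc1ccc(CN2CCN(CC(=O)Nc3ccc(-c4nc(-c5ccccc5)c(-c5ccccc5)n4C)cc3)CC2)cc1` is not yet measured. It differs from compound 2 in one place: 4-methylbenzyl in place of phenyl on an amine nitrogen in a ring. For the measured compounds named here, the only measured step on this ring nitrogen is the one from ethyl to phenyl, which raised the read-out; no step from phenyl to a benzyl-type group exists, so the change to 4-methylbenzyl rests on that single step alone. The entering group keeps a six-membered aromatic ring of carbon only, and compound 2 with phenyl at this nitrogen gives 60.5%. The expected step is therefore a number 5.5 percentage points lower from compound 2 to compound 3 (within the scatter), within or near the scatter. For compound 3 the estimate in this assay is 55%, with a range from 35% to 72%.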

Compound 3, a percentage reported as activity, at one concentration (the size of the read-out at that concentration, not a potency): 42.3%
Beside the measured number, compound 3's estimate is 12.7 percentage points above it; measured number inside the range.
By their numbers in this assay, from the lowest: compounds 1 and 3 (each within the scatter of the next); then compound 2.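

In this assay, for the compounds shown here, the ring nitrogen proves more selective than the single ethyl-to-phenyl step could show: the change gives a number 18.2 percentage points lower from compound 2 to compound 3 (beyond the scatter) even though the entering 4-methylbenzyl group keeps a six-membered aromatic ring of carbon only. An aromatic ring in the entering group is therefore not enough to keep the level of compound 2. The other new comparison, 4-methylphenyl in place of methyl on the saturated chain carbon, gives a number 3.5 percentage points higher from compound 1 to compound 3 (within the scatter) and so leaves compound 1 and compound 3 indistinguishable in this read-out, with compound 2 alone standing apart among the three; nothing measured accounts for these steps.

Open, from the compounds shown here alone, is whether the carbon link or the methyl group on the ring carries the loss. Unsubstituted benzyl and directly attached 4-methylphenyl would separate the two, and a pyridyl ring would test the all-carbon ring itself.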